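This account rests on a few compounds, and the source may have more. Where it says the series, first, only, none or still open, it means among the compounds named here.

Of the compounds shown here, three sharing one core have been tested so far in a functional assay on MGC-803 cells (Homo sapiens) for inhibition, read by sulforhodamine B assay; a lower number here means a stronger inhibitor, a higher number a weaker inhibitor. Compound 3 `O=C1C=C(N2CCCCC2)C(=O)c2c1nc1n2[C@H]2OC[C@@H](O)[C@H]2OC1` carries piperidin-1-yl on a double-bonded ring carbon. Compound 3 reads > 8000 nM, which is a limit of the assay and not a number. Compound 1 `O=C1C=C(NC2CCCCC2)C(=O)c2c1nc1n2[C@H]2OC[C@@H](O)[C@H]2OC1`, with cyclohexylamino at that place, reads > 8000 nM, also a limit. Most of the series so far sits at one value: the limit of > 8000 nM in this assay, at which 2 of the 3 values shown sit. Compound 2 `O=C1C=C(Nc2ccc(C(F)(F)F)cc2)C(=O)c2c1nc1n2[C@H]2OC[C@@H](O)[C@H]2OC1` gives a true number, 2820 nM. The change from cyclohexyl to 4-(trifluoromethyl)phenyl on the amine nitrogen is an at least 2.8-fold lower number from compound 1 to compound 2 (0.45 log units; beyond the scatter). The other measured step, a step that the two limits leave unreadable from compound 1 to compound 3, gives no guide to size.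

Compound 4 `O=C1C=C(Nc2cccc(Cl)c2)C(=O)c2c1nc1n2[C@H]2OC[C@@H](O)[C@H]2OC1` differs from compound 3 by (3-chlorophenyl)amino in place of piperidin-1-yl on a double-bonded ring carbon. Like compound 2, it has an aromatic ring on the amine nitrogen, so a modest move to a lower number in this assay is expected, on the evidence of an at least 2.8-fold lower number from compound 1 to compound 2 (0.45 log units; beyond the scatter). That single step is thin support. The estimated change is an at least 2.6-fold lower number from compound 3 to compound 4 (0.42 log units; beyond the scatter). For compound 4 the expected value is 3000 nM, with an estimated range from 1200 nM to 8000 nM.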

Compound 4, half-maximal inhibitory concentration: 1770 nM
Beside the measured number, compound 4's estimate is 1.7-fold (0.23 log units) above it; low and high end bracket the measured number.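

In this assay the change to (3-chlorophenyl)amino on the double-bonded ring carbon is an at least 4.5-fold lower number from compound 3 to compound 4 (0.65 log units; beyond the scatter) and, from the cyclohexylamino group, an at least 4.5-fold lower number from compound 1 to compound 4 (0.65 log units; beyond the scatter) so a second aromatic ring on the amine nitrogen now gives a true number. Changing the ring itself from 4-(trifluoromethyl)phenyl to 3-chlorophenyl is a 1.6-fold lower number from compound 2 to compound 4 (0.20 log units; within the scatter) and so shows no real difference between these two rings. Compound 1 and compound 3, the two without an aromatic ring there, stay at a limit of the assay and not a number: the limit of > 8000 nM in this assay, at which 2 of the 4 values shown sit.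

Still open, as far as these compounds go, is whether an unsubstituted phenyl ring, or a ring carrying a methoxy group or an amine, would also give a true number. A methyl group on the amine nitrogen of an aromatic amine would test whether that nitrogen's hydrogen matters.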